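The compounds below may be only part of what the source reports. "The series", "measured", "known", "first", "only" and "open" are said of these compounds alone.

Measured compounds in the series:

Compound 1, `O=C(O)c1ccc(C(=O)c2ccc(C(=O)c3ccc(Cl)cc3Cl)cc2)cc1`: 35 nM in an assay on CHO cells for inhibition of 3-oxo-5-alpha-steroid 4-dehydrogenase 2 (Homo sapiens); a higher number here means a weaker inhibitor, a lower number a stronger inhibitor
Compound 2, `O=C(O)c1ccc(C(=O)c2ccc(C(=O)C3CCCCC3)cc2)cc1`: 30 nM in this assay

Among the measured compounds shown here, compound 2 gives the lowest of the two numbers in this assay; its nearest neighbour is compound 1, and the single step of a 1.2-fold lower number from compound 1 to compound 2 (0.07 log units; within the scatter) is within the scatter, so the two compounds are not distinguishable in this assay.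

The next compound, compound 3, `O=C(O)c1ccc(C(=O)c2ccc(C(=O)Cc3ccccc3)cc2)cc1`, differs from compound 2 by benzyl in place of cyclohexyl on a carbonyl carbon. For the measured compounds named here, no measured step bears on this change directly: the one step on record, a 1.2-fold lower number from compound 1 to compound 2 (0.07 log units; within the scatter), exchanged an aromatic ring for a saturated one on the same carbonyl carbon and moved the number by nothing beyond the scatter. On that basis no step beyond the scatter is expected for compound 3 in this assay, and the estimate is 40 nM with a range of 12 nM to 130 nM, corresponding to an expected step of a 1.3-fold higher number from compound 2 to compound 3 (0.12 log units; within the scatter).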

Compound 3, inhibition constant: 40 nM
Estimate against measurement, compound 3: no gap at the digits printed; low and high end bracket the measured number.
By their numbers in this assay, from the lowest: compounds 2, 1 and 3 (each within the scatter of the next).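

Benzyl on the carbonyl carbon now stands with cyclohexyl and 2,4-dichlorophenyl in this assay, with a 1.3-fold higher number from compound 2 to compound 3 (0.12 log units; within the scatter) and a 1.1-fold higher number from compound 1 to compound 3 (0.06 log units; within the scatter), so neither change moves the number beyond the scatter. Benzyl is the only one of the three groups whose ring is not attached directly to the carbonyl carbon, so among these compounds direct attachment of the ring makes no difference beyond the scatter in this assay.

Still open is whether a group bearing an amine, a hydroxyl or a carboxylic acid at this carbonyl carbon, or a longer chain such as 2-phenylethyl, would stay within the scatter of these compounds. Going by these compounds, a small group such as methyl is also open, so whether a ring is needed here at all cannot be said. No independent measurement bears on why these three groups read alike.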